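The source may report more compounds than this note shows. Statements on the series, on what has been measured and on what is new or still open speak of the compounds shown alone.

Among the measured compounds shown here, in an ADME assay for permeability, using PAMPA, at pH 4 (a higher number here means that the compound crosses the layer faster, a lower number that the compound crosses the layer more slowly), compound 1 `Cc1[nH]c2ccccc2c(=O)c1Cc1ccccc1` gives 110 10^-6 cm/s and compound 2 `COc1cccc2[nH]c(C)c(Cc3ccccc3)c(=O)c12` gives 69.8 10^-6 cm/s, so compound 2 stands within the usual scatter of the only other measured number. Compound 3 `Cc1[nH]c2cccc(Cl)c2c(=O)c1Cc1ccccc1` has not yet been measured. It carries chloro in place of methoxy on an aromatic carbon. For the measured compounds named here, one measured step bears on this change, and it involves the methoxy group: a 1.6-fold lower number from compound 1 to compound 2 (0.20 log units; within the scatter), seen when methoxy took the place of hydrogen on an aromatic carbon. Going by the values given here, no measured compound carries chloro, so that evidence is indirect. Among the compounds with values here, with only this small step as a guide, no step beyond the scatter is expected in this assay, and no direction can be firmly expected. The estimate amounts to an expected 1.3-fold higher number from compound 2 to compound 3 (0.11 log units; within the scatter). For compound 3 the estimated value is 90 10^-6 cm/s, with an expected range from 40 10^-6 cm/s to 190 10^-6 cm/s.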

Compound 3, apparent permeability in the ADME assay: 244 10^-6 cm/s
Beside the measured number, compound 3's estimate is 2.7-fold (0.43 log units) below it; measured number above the stated range.
By their numbers in the ADME assay, from the lowest: compounds 2 and 1 (each within the scatter of the next); then compound 3.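

In the ADME assay this aromatic carbon now shows steps beyond the scatter, which the earlier step from hydrogen to methoxy did not: chloro in place of hydrogen gives a 2.2-fold higher number from compound 1 to compound 3 (0.35 log units; beyond the scatter), and chloro in place of methoxy gives a 3.5-fold higher number from compound 2 to compound 3 (0.54 log units; beyond the scatter). The same exchange of methoxy for chloro moves the number the opposite way in a physicochemical assay for solubility, read by HPLC, at pH 7.4 (a lower number here means a less soluble compound, a higher number a more soluble compound), where it gives an at least 10-fold lower number from compound 2 to compound 3 (1.00 log units; beyond the scatter). In the physicochemical assay compound 3 gives 2000 nM. In the physicochemical assay compound 2 gives > 20000 nM, which is a limit of the assay and not a number, so the full size of that step stays unknown: the limit of > 20000 nM in the physicochemical assay, at which 1 of the 2 values shown sits.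

On these data alone, whether a step of this size is special to chloro stays open, as does how a fluoro, a methyl or an amine on this aromatic carbon would compare. The compounds shown also do not tell whether chloro on another aromatic carbon of the shared core would give similar steps.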